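Moving the nitro group on the benzyl ring of compound 3

The compounds below may be only part of what the source reports. "The series", "measured", "known", "first", "only" and "open" are said of these compounds alone.

Compound 3, `COc1cccc(OC)c1OCCNCCOc1ccccc1OCc1cccc([N+](=O)[O-])c1`, stands highest among the three compounds measured in a functional assay on Vas deferens for antagonist activity at Alpha-1A adrenergic receptor (Rattus norvegicus) (on this read-out higher numbers stand for higher potency (the scale is a negative logarithm) and lower numbers for lower potency), with a value of 8.85. Its nearest neighbour is compound 2, `COc1cccc(OC)c1OCCNCCOc1ccccc1OCc1cccc(C)c1`, which gives 8.3, and the furthest is compound 1, `COc1cccc(OC)c1OCCNCCOc1ccccc1OCc1ccccc1C`, which gives 7.81. The steps that separate them, a number 0.49 log units higher from compound 1 to compound 2 (beyond the scatter), a number 1.04 log units higher from compound 1 to compound 3 (beyond the scatter) and a number 0.55 log units higher from compound 2 to compound 3 (beyond the scatter), are all beyond the scatter.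

Compound 4, `COc1cccc(OC)c1OCCNCCOc1ccccc1OCc1ccc([N+](=O)[O-])cc1`, differs from compound 3 by 4-nitrophenyl in place of 3-nitrophenyl on a saturated chain carbon bound to an oxygen on an aromatic ring. Among the compounds with values here, no measured step moves a nitro group from one ring position to another; the only measured change of position is the one from compound 1 to compound 2, which was modest in size, and it concerns a methyl group, not a nitro group. On this basis the author expects in this assay a step from compound 3 to compound 4 of a number 0.25 log units lower from compound 3 to compound 4 (within the scatter), within the scatter, and a value for compound 4 estimated at 8.6, ranging from 8 to 9.2.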

Compound 4, negative logarithm of the antagonist equilibrium constant: 8.58
Beside the measured number, compound 4's estimate is 0.02 log units above it; measured number inside the range.
By their numbers in this assay, from the lowest: compound 1; then compounds 2, 4 and 3 (each within the scatter of the next, the first and the last beyond it).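

In this assay, moving the nitro group gives a number 0.27 log units lower from compound 3 to compound 4 (within the scatter), the first measured change of position for this group, and it leaves 3-nitrophenyl and 4-nitrophenyl within the scatter of each other, whereas the one methyl change of position shown, a number 0.49 log units higher from compound 1 to compound 2 (beyond the scatter), lies beyond it. Compound 4 also stands within the scatter of the 3-methylphenyl compound, a number 0.28 log units higher from compound 2 to compound 4 (within the scatter), but remains clearly apart from the 2-methylphenyl compound, a number 0.77 log units higher from compound 1 to compound 4 (beyond the scatter). Nothing available here accounts for these differences.

The compounds shown leave open whether an amine or a carboxylic acid in place of the nitro group on the 4-nitrophenyl would stay within the scatter of compound 4. They also leave open what a longer chain in place of the saturated chain carbon would do.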